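Compound 4 from compound 3: amide-arm swap

This account rests on a few compounds, and the source may have more. Where it says the series, first, only, none or still open, it means among the compounds named here.

Series notes. Compound 1 `O=C(NC1CCCCC1)c1nc[nH]c1C(=O)Nc1ccc(Cl)c(Cl)c1` carries a cyclohexyl arm on one amide nitrogen, and in a functional assay on HL-60 cells (Homo sapiens), with a stated time of 2 days (a higher number here means a weaker inhibitor, a lower number a stronger inhibitor), compound 1 gives 33100 nM. Going by the values given here, compound 2 `O=C(NCc1ccccc1)c1nc[nH]c1C(=O)Nc1ccc(Cl)c(Cl)c1` carries a benzyl arm there, and in this assay compound 2 gives 11500 nM; the one step between measured compounds differing in a single place is a 2.9-fold lower number from compound 1 to compound 2 (0.46 log units; beyond the scatter). Compound 3 `O=C(Nc1ccc(Cl)c(Cl)c1)c1nc[nH]c1C(=O)NCc1ccc(Cl)cc1` carries a 4-chlorobenzyl arm, and in this assay compound 3 gives 16200 nM, the second highest of the three numbers: nearest is compound 2, within the scatter, furthest is compound 1, beyond the scatter.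

Compound 4 `CC(C)(C)OC(=O)CNC(=O)c1[nH]cnc1C(=O)Nc1ccc(Cl)c(Cl)c1` differs from compound 3 by tert-butoxycarbonyl in place of 4-chlorophenyl on a saturated chain carbon bound to an amide-type nitrogen. Among the compounds with values here, no measured step exchanges 4-chlorophenyl for tert-butoxycarbonyl on that chain carbon; the step from compound 1 to compound 2 bears on it only in that it alters the same arm, and it was modest. For compound 4 the expected step is therefore a 1.2-fold higher number from compound 3 to compound 4 (0.09 log units; within the scatter), nothing clearly beyond the scatter. Compound 4 is estimated at 20000 nM in this assay, within 6000 nM to 60000 nM.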

Compound 4, half-maximal inhibitory concentration: 49800 nM
Compound 4: middle estimate off by 2.5-fold (0.40 log units), on the low side, and the stated range covers the measured number.
By their numbers in this assay, from the lowest: compounds 2 and 3 (each within the scatter of the next); then compounds 1 and 4 (each within the scatter of the next).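

The arm on this amide-type nitrogen also responds in this assay when its ring is replaced by a ring-free group carrying hydrogen-bond acceptors: tert-butoxycarbonyl in place of 4-chlorophenyl raises the number (a 3.1-fold higher number from compound 3 to compound 4 (0.49 log units; beyond the scatter)). Together with the modest step of a 2.9-fold lower number from compound 1 to compound 2 (0.46 log units; beyond the scatter) where benzyl replaces cyclohexyl, both steps at this arm favour the aromatic ring, though only these two steps support that reading and neither is large. Nothing available accounts for the step.

The compounds shown do not separate loss of the aromatic ring from entry of the ester. A carboxylic acid, an amine or a plain alkyl chain on the same saturated chain carbon would tell these apart, and a ring-free arm without a carbonyl would show what the ring alone contributes.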